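Replacing a Hydroxy Group with Propyl on a Methylated Core

The source may hold more compounds than are shown below. What is called first, only, known or untested is meant among the compounds shown, and "the series" means these compounds.

Measured so far:
compound 1 `CCCCCc1cc2nn(-c3ccccc3)cc2cn1` — 2100 nM
compound 2 `Cc1nc(CCO)cc2nn(-c3ccccc3)cc12` — > 100000 nM
compound 3 `OCCc1cc2nn(-c3ccccc3)cc2cn1` — > 100000 nM

Compound 2 sits at a limit of the assay, not at a number: in a functional assay on K562 cells (Homo sapiens) for inhibition, read by fluorescence, with a stated time of 72 h (a higher number here means a weaker inhibitor of growth, a lower number a stronger inhibitor of growth), compound 2 gives > 100000 nM. The same limit holds for compound 3, which in this assay gives > 100000 nM. Only compound 1 carries a real number, 2100 nM in this assay, so it is the one fixed point among the three.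

Compound 4 `CCCCCc1cc2nn(-c3ccccc3)cc2c(C)n1` differs from compound 2 in one place: propyl in place of hydroxy on a saturated chain carbon, two bonds along the chain from an aromatic carbon. The same exchange, in the opposite direction, has already been measured once: an at least 47-fold higher number from compound 1 to compound 3 (1.67 log units; beyond the scatter). The other measured step, a step that the two limits leave unreadable from compound 2 to compound 3, changes only a methyl on an aromatic carbon and cannot be read, since the limit of > 100000 nM in this assay, at which 2 of the 3 values shown sit, applies to both of its compounds.

Replacing hydroxy by propyl is therefore expected to lower the number by a large amount, and compound 4 is expected to reach the region of compound 1. The step of an at least 40-fold lower number from compound 2 to compound 4 (1.60 log units; beyond the scatter) is the estimated size of this change. For compound 4 the estimate in this assay is 2500 nM, within a range from 500 nM to 15000 nM.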

Compound 4, concentration for 50% growth inhibition: 6900 nM
The estimate for compound 4 lay 2.8-fold (0.44 log units) below the measured number, within the range that was stated.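

In this assay, propyl in place of hydroxy on a saturated chain carbon, two bonds along the chain from an aromatic carbon, also gives a large gain on the methylated core, with an at least 14-fold lower number from compound 2 to compound 4 (1.16 log units; beyond the scatter). The same exchange has now been seen on two cores, pointing the same way on both, but its size cannot be compared between them: the same change on two cores in this assay, an at least 47-fold higher number (1.67 log units; beyond the scatter) from compound 1 to compound 3 and an at least 14-fold higher number (1.16 log units; beyond the scatter) from compound 4 to compound 2; the limit leaves it open whether they differ

The methyl on an aromatic carbon, whose step could not be read among the hydroxy compounds, can now be read in the pentyl pair, and methyl in place of hydrogen gives a 3.3-fold higher number from compound 1 to compound 4 (0.52 log units; beyond the scatter), a modest step beyond the scatter but much smaller than the change at the chain.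

Any step between the two hydroxy compounds still cannot be read, and how weak either of them truly is stays unknown, as both sit at a limit of the assay: the limit of > 100000 nM in this assay, at which 2 of the 4 values shown sit.

Going by these compounds, it also stays open whether a chain longer than pentyl, or a chain ending in an amine or a carboxylic acid, would give a lower or a higher number than compound 1 on the shared core.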